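The compounds below may be only part of what the source reports. "The series", "measured", "known", "first", "only" and "open" are said of these compounds alone.

Measured so far in a functional assay on KB 3-1 cells (Homo sapiens) for cytotoxicity, read by MTT assay, with a stated time of 68 h; a lower number here means a stronger inhibitor, a higher number a weaker inhibitor:
Compound 1 `Nc1cccc(-c2cccc(NC(=O)C(Cl)Cl)c2)c1`: 26100 nM.
Compound 2 `O=C(Nc1cccc(-c2cccc(F)c2)c1)C(Cl)Cl`: > 50000 nM.
Compound 3 `Cc1cccc(-c2cccc(NC(=O)C(Cl)Cl)c2)c1`: > 50000 nM.

The values for compound 2 and compound 3 are limits of the assay and not numbers, and only compound 1 has a true number. Compound 3 therefore has no exact place in the series. It sits with compound 2 in the group described by the limit of > 50000 nM in this assay, at which 2 of the 3 values shown sit.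

Compound 4 `O=C(Nc1cccc(-c2cccc(Cl)c2)c1)C(Cl)Cl` makes a single change to compound 3: chloro in place of methyl on an aromatic carbon. In words, chloro takes the place of methyl on an aromatic carbon, meta to a large group.

Among the compounds with values here, three measured steps bear on this change. Replacing amino with fluoro gave an at least 1.9-fold higher number from compound 1 to compound 2 (0.28 log units; that floor lies within the scatter), and replacing amino with methyl gave an at least 1.9-fold higher number from compound 1 to compound 3 (0.28 log units; that floor lies within the scatter). The closest comparison, replacing fluoro with methyl, gave a step that the two limits leave unreadable from compound 2 to compound 3. Compound 4 also lacks the amino group, so the two compounds without it are its best guide. No step beyond the scatter is therefore expected in this assay, and no direction can be predicted with confidence. Compound 4 is estimated at 45000 nM, with an expected range from 20000 nM to 90000 nM. The estimated step is an at least 1.1-fold lower number from compound 3 to compound 4 (0.04 log units; that floor lies within the scatter).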

Compound 4, half-maximal inhibitory concentration: > 50000 nM
Compound 4 ended at the assay's limit; the forecaster's own chance of this, stated with the estimate: 60%; middle value at least 1.1-fold (0.04 log units) from the limit.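

In this assay compound 4 gives > 50000 nM, which is a limit of the assay and not a number. Chloro therefore joins fluoro and methyl at this position without giving a true number, and the steps among compound 2, compound 3 and compound 4 cannot be read; the one new step that can be read is an at least 1.9-fold higher number from compound 1 to compound 4 (0.28 log units; that floor lies within the scatter). With a third group in place of amino ending at the same limit, compound 1 remains the only compound with a true number, and the rest of the series gives no measured order: the limit of > 50000 nM in this assay, at which 3 of the 4 values shown sit.

Going by these compounds, whether amino truly sets compound 1 apart remains open, as the step from it to compound 4, like those to compound 2 and compound 3, has a floor that lies within the scatter. The compounds shown also leave open whether a hydroxyl group, a carboxylic acid or a dimethylamino group on this aromatic carbon would give a true number in this assay.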